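This account rests on a few compounds, and the source may have more. Where it says the series, first, only, none or still open, it means among the compounds named here.

Working notes on the series. Compound 1 `CNc1cc(Oc2c(F)cc(NC(=O)Nc3cccc(C(F)(F)F)c3)cc2F)ncn1` is assayed in an assay on isolated protein for inhibition of serine/threonine-protein kinase TNNI3K (Homo sapiens) (on this read-out higher numbers stand for weaker inhibition and lower numbers for stronger inhibition), and gives 20 nM. Compound 2 `CC(C)Nc1cc(Oc2ccc(NC(=O)Nc3cccc(C(F)(F)F)c3)cc2)ncn1` gives 40 nM in this assay, and compound 3 `C[C@H](O)CNc1cc(Oc2ccc(NC(=O)Nc3cccc(C(F)(F)F)c3)cc2)ncn1` gives 32 nM. Going by the values given here, the one single-point step measured so far, a 1.3-fold lower number from compound 2 to compound 3 (0.10 log units; within the scatter), concerns the substituent on the amine and stays within the scatter. On the numbers shown, compound 1 sits at the low end of the three, but its gap to compound 3 and its gap to compound 2 both lie within the scatter, so the three numbers cannot be separated.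

Compound 4 `CNc1cc(Oc2ccc(NC(=O)Nc3cccc(C(F)(F)F)c3)cc2F)ncn1` is not yet measured. It differs from compound 1 as follows: hydrogen in place of fluoro on an aromatic carbon. Among the compounds with values here, no measured step touches a fluoro group on this ring; the only step known, from compound 2 to compound 3, alters the amine substituent and bears on the present change only in showing how little the series has moved so far. Compound 2 and compound 3 carry no fluoro group on that ring at all, and their values in this assay stay within the scatter of compound 1. Removing one fluoro is therefore expected to produce no step beyond the scatter, a 1.3-fold higher number from compound 1 to compound 4 (0.10 log units; within the scatter). Compound 4 is estimated at 25 nM in this assay, with a range of 12 nM to 50 nM.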

Compound 4, half-maximal inhibitory concentration: 25 nM
Compound 4: the middle estimate sits on the measured number at the digits printed; low and high end bracket the measured number.
By their numbers in this assay, from the lowest: compounds 1, 4, 3 and 2 (each within the scatter of the next).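

In this assay, going by these compounds alone, hydrogen in place of fluoro on the aromatic carbon ortho to a (6-(methylamino)pyrimidin-4-yl)oxy group gives a 1.3-fold higher number from compound 1 to compound 4 (0.10 log units; within the scatter), the only measured step at this position. Within the data shown here, with the methylamino group and the remaining fluoro held constant, fluoro and hydrogen at this position cannot be told apart on this read-out, a finding the amine step from the earlier compounds could not supply. No available evidence bears on why this step stays within the scatter.

The compounds shown leave open what loss of the remaining fluoro would do with the methylamino group held constant, since compound 2 and compound 3 lack both fluoro groups but also carry different amine substituents and so give no single-place comparison. Among these compounds, also open is whether a larger or different group at this position, such as chloro, methyl or methoxy, would move the number beyond the scatter, as the single step here spans only fluoro and hydrogen.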